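This account rests on a few compounds, and the source may have more. Where it says the series, first, only, none or still open, it means among the compounds named here.

Measured so far in a functional assay on the whole organism for inhibition, with Mus musculus as the target, in the writhing test, with a stated time of 15 min, at a dose of 10 mg/kg; on this read-out lower numbers stand for less inhibition and higher numbers for more inhibition at the one dose given (going by the name of the read-out):

compound 1 `COc1ccc(C2CC(C3C(=O)c4ccccc4C3=O)=NC(=O)N2)cc1` — 31%
compound 2 `O=C1N=C(C2C(=O)c3ccccc3C2=O)CC(c2cccc([N+](=O)[O-])c2)N1` — 36%

Compound 1 holds the lowest of the two numbers. Going by the values given here, its only neighbour is compound 2, and the step between them is a number 5 percentage points higher from compound 1 to compound 2 (within the scatter), so the two values cannot be told apart on this read-out.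

Compound 3 `O=C1N=C(C2C(=O)c3ccccc3C2=O)CC(/C=C/c2ccccc2)N1` is the next unmeasured member. Against compound 1 the change is 2-phenylethenyl in place of 4-methoxyphenyl on a saturated ring carbon. Among the compounds with values here, the one measured step that bears on it is the replacement on the same saturated ring carbon, 3-nitrophenyl in place of 4-methoxyphenyl, which gave a number 5 percentage points higher from compound 1 to compound 2 (within the scatter). That step shares the place of the change but not the entering group; nothing measured here involves 2-phenylethenyl, and nothing here tests a group with a double bond outside aromatic rings at this position. With only a within-scatter precedent at this site, no step beyond the scatter is expected in either direction, and the estimate stays close to compound 1 with a wide range.

For compound 3 the expected value in this assay is 33%, with a range from 18% to 48%. This corresponds to an expected step of a number 2 percentage points higher from compound 1 to compound 3 (within the scatter).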

Compound 3, a percentage reported as inhibition, in the whole organism at one dose (the size of the read-out at that dose, not a potency): 16%
Compound 3: middle estimate off by 17 percentage points, on the high side; measured number below the stated range.
By their numbers in this assay, from the lowest: compound 3; then compounds 1 and 2 (each within the scatter of the next).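

Working notes on the series: in this assay, the saturated ring carbon next to the ring nitrogen now shows that it responds to the group it carries, since 2-phenylethenyl in place of 4-methoxyphenyl gives a number 15 percentage points lower from compound 1 to compound 3 (beyond the scatter) and 2-phenylethenyl in place of 3-nitrophenyl gives a number 20 percentage points lower from compound 2 to compound 3 (beyond the scatter), whereas the exchange of the two substituted phenyl groups gave only a number 5 percentage points higher from compound 1 to compound 2 (within the scatter). Compared with 4-methoxyphenyl, 2-phenylethenyl keeps the heavy-atom count and the six-membered aromatic ring but adds a double bond outside aromatic rings and has no hydrogen-bond acceptor, so a matched count of heavy atoms does not by itself keep the number level at this position. No supporting information on the origin of this lower number is available for the series.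

The compounds shown leave open whether the double bond itself or the placing of the phenyl ring away from the saturated ring carbon goes with the lower number, a question that 2-phenylethyl at the same carbon would address. Also open, on these data alone, is how an unsubstituted phenyl or a phenyl carrying an amine or a carboxylic acid would read at this position.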